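This account rests on a few compounds, and the source may have more. Where it says the series, first, only, none or still open, it means among the compounds named here.

Within the data shown here, compound 1 `O=C1Nc2c(ccc(F)c2F)C1(c1ccccc1)c1ccc(O)cc1` is the only compound with a single number in a functional assay on PC-3 cells (Homo sapiens) for cytotoxicity, read by WST assay, with a stated time of 72 h (on this read-out higher numbers stand for weaker inhibition and lower numbers for stronger inhibition), where compound 1 gives 8.9 nM. Compound 2 `COc1ccc(C2(c3ccc(O)cc3)C(=O)Nc3c2ccc(F)c3F)cc1` gives 2 nM; 2.2 nM; > 1000 nM (3 entries) in this assay. One of those three entries for compound 2 is a limit of the assay (the limit of > 1000 nM in this assay, at which 1 of the 3 values shown sits). Compound 3 `O=C1Nc2c(ccc(F)c2F)C1(CC1CCCCC1)c1ccc(O)cc1` gives > 1000 nM in this assay, which is a limit and not a number. The move to compound 4 `O=C1Nc2c(ccc(F)c2F)C1(Cc1ccccc1)c1ccc(O)cc1` is benzyl in place of phenyl on a saturated ring carbon. Among the measured compounds shown here, the one measured step that bears on it, an at least 110-fold higher number from compound 1 to compound 3 (2.05 log units; beyond the scatter), also replaces phenyl on the same saturated ring carbon and was large, so a weakening is expected, and because an at least 110-fold higher number from compound 1 to compound 3 (2.05 log units; beyond the scatter) was so large, compound 4 may itself end at the limit. Compound 4 is expected near 300 nM, within 40 nM to 2000 nM. The expected step is a 34-fold higher number from compound 1 to compound 4 (1.53 log units; beyond the scatter).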

Compound 4, half-maximal inhibitory concentration: > 1000 nM
Compound 4 ended at the assay's limit (the forecaster's own chance of this, stated with the estimate: 35%); middle value at least 3.3-fold (0.52 log units) from the limit.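

With an at least 110-fold higher number from compound 1 to compound 4 (2.05 log units; beyond the scatter), benzyl keeps the one six-membered aromatic ring of phenyl and still does not hold the value of compound 1 in this assay. The loss seen with cyclohexylmethyl thus also appears with that aromatic ring kept, once a chain carbon stands between it and the saturated ring carbon. The step from compound 3 to compound 4 cannot be read, as both values are limits: the limit of > 1000 nM in this assay, at which 2 of the 4 values shown sit.

As far as these compounds go, whether an amine or a carboxylic acid on the benzyl ring would bring back a measurable number stays open. From the compounds shown here alone, the true size of the loss also stays open.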